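Replacing 4-fluorobenzyl with 3-(dimethylamino)propyl

The source may hold more compounds than are shown below. What is called first, only, known or untested is meant among the compounds shown, and "the series" means these compounds.

Compound 1 `CS(=O)(=O)Oc1c(C(=O)NCc2ccc(F)cc2)nc(Br)c2cccnc12`: > 20000 nM
Compound 2 `O=C(NCc1ccc(F)cc1)c1nc(Br)c2cccnc2c1NCc1ccc(F)cc1`: > 20000 nM

Both entries come from a functional assay on MDA-MB-435 cells (Homo sapiens) for cytotoxicity, read by MTT assay, with a stated time of 72 h; a lower number here means a stronger inhibitor, a higher number a weaker inhibitor. Compound 2 has no numerical value there, only the limit > 20000 nM. Compound 1 also gives only a limit, > 20000 nM. The sole reference point for the series is therefore (the limit of > 20000 nM in this assay, at which 2 of the 2 values shown sit).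

Compound 3 `CN(C)CCCNc1c(C(=O)NCc2ccc(F)cc2)nc(Br)c2cccnc12` keeps the core of compound 2 and alters its side chain: 2-(dimethylamino)ethyl in place of 4-fluorophenyl on a saturated chain carbon bound to a nitrogen on an aromatic ring. Cut one bond further out, this is 3-(dimethylamino)propyl in place of 4-fluorobenzyl. Going by the values given here, the only measured step that bears on this change is a step that the two limits leave unreadable from compound 1 to compound 2. It offers no size to carry over, and neither measured compound gives a number to build on. Any expectation in this assay is therefore weak. Compound 3 is expected to stay close to the limit of compound 2, at best slightly stronger, and it may well return a limit again. The expected change is an at least 1.3-fold lower number from compound 2 to compound 3 (0.12 log units; that floor lies within the scatter). For compound 3 the estimated value is 15000 nM, with an expected range of 4000 nM to 30000 nM.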

Compound 3, half-maximal inhibitory concentration: 7000 nM
The estimate for compound 3 lay 2.1-fold (0.33 log units) above the measured number; measured number inside the range.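

In this assay, compound 3 is the only one of the three compounds shown to give a number rather than a limit, which gives this position its first readable steps. Putting 2-(dimethylamino)ethyl in place of 4-fluorophenyl on a saturated chain carbon bound to a nitrogen on an aromatic ring gives an at least 2.8-fold lower number from compound 2 to compound 3 (0.45 log units; beyond the scatter), and putting (3-(dimethylamino)propyl)amino in place of (methylsulfonyl)oxy on an aromatic carbon gives an at least 2.8-fold lower number from compound 1 to compound 3 (0.45 log units; beyond the scatter), while the remaining step, which joins two limits, cannot be read. Both readable steps are floors with no upper size, and the other two compounds supply only one shared reference point: the limit of > 20000 nM in this assay, at which 2 of the 3 values shown sit.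

The compounds shown do not separate the loss of the 4-fluorophenyl ring from the arrival of the dimethylamino group, so it remains open which of the two goes with the lower number. A plain propyl chain, a primary amine at the end of the chain, or a piperidine in place of the dimethylamino group would each bear on this question, as would a longer chain carrying the same dimethylamino group.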